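Replacing the dimethylamino end group with a chlorophenyl

The compounds below may be only part of what the source reports. "The series", "measured", "known", "first", "only" and "open" are said of these compounds alone.

compound 1 `c1ccc(-c2ccc(-c3ccc(-c4nc5ccccc5[nH]4)cc3)cc2)cc1`: 41200 nM
compound 2 `Cc1ccc2[nH]c(-c3ccc(-c4ccc(-c5ccc(N(C)C)cc5)cc4)cc3)nc2c1`: 8120 nM

In a functional assay on PC-3 cells (Homo sapiens) for inhibition, read by sulforhodamine B assay (a lower number here means a stronger inhibitor of growth, a higher number a weaker inhibitor of growth), compound 2 gives the lower of the two numbers, 8120 nM, and its gap to compound 1 lies beyond the scatter. Compound 3 `Cc1ccc2[nH]c(-c3ccc(-c4ccc(-c5cccc(Cl)c5)cc4)cc3)nc2c1` carries 3-chlorophenyl in place of 4-(dimethylamino)phenyl on an aromatic carbon. Among the measured compounds shown here, no measured pair shows this exchange alone, so any forecast is loose. Compound 1, which also lacks the 4-(dimethylamino)phenyl group, gives 41200 nM, so a weaker result is expected. The expected change a 1.8-fold higher number from compound 2 to compound 3 (0.27 log units; within the scatter) is a modest rise in the number. For compound 3 the estimated value is 15000 nM, with an expected range of 4000 nM to 45000 nM.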

Compound 3, concentration for 50% growth inhibition: 2670 nM
For compound 3 the middle estimate is 5.6-fold (0.75 log units) above the measured one, and the stated range ends above it.
By their numbers in this assay, from the lowest: compound 3; then compound 2; then compound 1.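

In this assay, the end ring at this position can be changed without losing activity: 3-chlorophenyl in place of 4-(dimethylamino)phenyl gives (a 3.0-fold lower number from compound 2 to compound 3 (0.48 log units; beyond the scatter)). Among the compounds shown here, this is the first exchange seen at this position alone, and it shows that the dimethylamino group is not required for the growth inhibition seen in compound 2. Nothing available explains the gain.

As far as these compounds go, it remains open whether the chlorine itself or its place on the ring matters most. How a 4-chlorophenyl or 3-methoxyphenyl end group would compare is also unknown.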